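Replacing morpholin-4-yl with dipropylamino on a thiocarbonyl carbon

The compounds below may be only part of what the source reports. "The series", "measured", "known", "first", "only" and "open" are said of these compounds alone.

Compound 1 `Oc1ccc(C2C/C(=N\NC(=S)N3CCOCC3)c3ccc(O)cc3O2)cc1` gives 84500 nM
Compound 2 `Oc1ccc(C2C/C(=N\NC(=S)N3CCCC3)c3ccc(O)cc3O2)cc1` gives 51700 nM

Going by the values given here, both values come from a functional assay on DU-145 cells (Homo sapiens) for cytotoxicity, read by MTT assay, with a stated time of 72 h (a lower number here means a stronger inhibitor, a higher number a weaker inhibitor), and lie within the scatter of each other, so compound 1 cannot be separated from the only other measured compound. Compound 3 `CCCN(CCC)C(=S)N/N=C1\CC(c2ccc(O)cc2)Oc2cc(O)ccc21` has not yet been measured. It shares the core of compound 1 and differs from it by one change, (dipropylamino in place of morpholin-4-yl on a thiocarbonyl carbon), which puts dipropylamino in place of morpholin-4-yl on a thiocarbonyl carbon.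

Among the compounds with values here, one measured step bears on this change: a 1.6-fold lower number from compound 1 to compound 2 (0.21 log units; within the scatter), with pyrrolidin-1-yl in place of morpholin-4-yl at the same place. That step stays within the scatter. Within the data shown here, it is a single step, and no measured compound carries dipropylamino, so it offers only a weak guide. On this evidence, no shift beyond the scatter is expected in this assay, and no direction can be firmly assigned. The expected step is a 1.7-fold lower number from compound 1 to compound 3 (0.23 log units; within the scatter). Compound 3 is estimated at 50000 nM, with an expected range from 20000 nM to 110000 nM.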

Compound 3, half-maximal inhibitory concentration: 62100 nM
The estimate for compound 3 lay 1.2-fold (0.09 log units) below the measured number; the range from low to high includes it.
By their numbers in this assay, from the lowest: compounds 2, 3 and 1 (each within the scatter of the next).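

In this assay, the position on the thiocarbonyl carbon now holds a group with no ring as well as two ring groups: dipropylamino in place of morpholin-4-yl gives a 1.4-fold lower number from compound 1 to compound 3 (0.13 log units; within the scatter) and dipropylamino in place of pyrrolidin-1-yl gives a 1.2-fold higher number from compound 2 to compound 3 (0.08 log units; within the scatter). Among these three compounds, then, neither giving up the ring nor giving up the oxygen of morpholin-4-yl, and with it the hydrogen-bond acceptor counted for that group, brings a shift beyond the scatter, so the three groups cannot be separated at this position. Nothing at hand offers a reason for this flat result.

Going by these compounds, whether any group on this thiocarbonyl carbon can move the number beyond the scatter stays open, for example a piperazine with a free ring amine, a chain ending in a carboxylic acid, or a chain longer than propyl. The compounds shown also tell nothing about the hydroxy groups of the shared core, since all three carry them unchanged.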